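Swapping Trifluoromethyl for Chloro on a Diaryl Urea

This account rests on a few compounds, and the source may have more. Where it says the series, first, only, none or still open, it means among the compounds named here.

Measured compounds:
compound 1 `COc1cc2cc(Oc3ccc(NC(=O)Nc4cccc(C(F)(F)F)c4)cc3)c(C)nc2cc1OC`: 1970 nM
compound 2 `COc1cc2cc(Oc3ccc(NC(=O)Nc4ccc(Cl)c(C(F)(F)F)c4)cc3)c(C)nc2cc1OC`: 1410 nM

In a functional assay on SK-MEL-28 cells (Homo sapiens) for inhibition, read by sulforhodamine B assay, with a stated time of 48 h (on this read-out higher numbers stand for weaker inhibition of growth and lower numbers for stronger inhibition of growth), compound 1 gives 1970 nM and compound 2 gives 1410 nM. The step of a 1.4-fold lower number from compound 1 to compound 2 (0.15 log units; within the scatter) lies within the scatter, so compound 2 stands level with compound 1 rather than apart from it. Compound 3 `COc1cc2cc(Oc3ccc(NC(=O)Nc4ccc(Cl)c(Cl)c4)cc3)c(C)nc2cc1OC` differs from compound 2 by chloro in place of trifluoromethyl on an aromatic carbon. Among the compounds with values here, no measured step exchanges these two groups for one another; the only step known, a 1.4-fold lower number from compound 1 to compound 2 (0.15 log units; within the scatter), concerns a different change and was itself small. A step beyond the scatter is therefore not expected. Compound 3 is estimated at 1800 nM, within 700 nM to 4500 nM, which means an expected step of a 1.3-fold higher number from compound 2 to compound 3 (0.11 log units; within the scatter).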

Compound 3, concentration for 50% growth inhibition: 3770 nM
Beside the measured number, compound 3's estimate is 2.1-fold (0.32 log units) below it; the range from low to high includes it.
By their numbers in this assay, from the lowest: compounds 2, 1 and 3 (each within the scatter of the next, the first and the last beyond it).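

Exchanging trifluoromethyl for chloro at this position gives a 2.7-fold higher number from compound 2 to compound 3 (0.43 log units; beyond the scatter) and so weakens growth inhibition modestly, which the earlier addition of chloro, a step within the scatter, did not show. Compound 3 still stands level with compound 1, with a 1.9-fold higher number from compound 1 to compound 3 (0.28 log units; within the scatter) as the printed step between them. No measured evidence here explains why this exchange costs activity.

On these data alone, whether a methyl, a nitrile or an amine at this position would match trifluoromethyl remains open. So does whether the same exchange would have a similar effect without the neighbouring chloro group.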